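This account rests on a few compounds, and the source may have more. Where it says the series, first, only, none or still open, it means among the compounds named here.

In an ADME assay on microsomes from liver (Rattus norvegicus) for metabolic stability, with a stated time of 10 min (a higher number here means that more of the compound is left, a lower number that less of the compound is left), three compounds have been measured:

Compound 1 `CC(C)C(=O)NCCS(=O)(=O)NC(=O)c1ccc(Nc2nc(NC3(c4ccc(Cl)cc4)CC3)nc(OCC(F)(F)F)n2)cc1`: 84%
Compound 2 `O=C(NS(=O)(=O)c1ccc(F)cc1)c1ccc(Nc2nc(NC3(c4ccc(Cl)cc4)CC3)nc(OCC(F)(F)F)n2)cc1`: 99%
Compound 3 `CS(=O)(=O)NC(=O)c1ccc(Nc2nc(NC3(c4ccc(Cl)cc4)CC3)nc(OCC(F)(F)F)n2)cc1`: 85%

Compound 1 gives the lowest of these three numbers; compound 3 is nearest, a number 1 percentage points higher from compound 1 to compound 3 (within the scatter), and compound 2 furthest, a number 15 percentage points higher from compound 1 to compound 2 (beyond the scatter). Compound 4 `O=C(NS(=O)(=O)CCNC(=O)C1CC1)c1ccc(Nc2nc(NC3(c4ccc(Cl)cc4)CC3)nc(OCC(F)(F)F)n2)cc1` has not yet been measured in this assay. It differs from compound 1 in one place: cyclopropyl in place of isopropyl on a carbonyl carbon. Going by the values given here, no measured step touches this carbonyl carbon. The larger steps of a number 15 percentage points higher from compound 1 to compound 2 (beyond the scatter) and a number 14 percentage points lower from compound 2 to compound 3 (beyond the scatter) concern the group on the sulfonyl sulfur. Given that removing the whole ((isopropylcarbonyl)amino)methyl group gave only a number 1 percentage points higher from compound 1 to compound 3 (within the scatter), exchanging one small piece inside it is expected to give no step beyond the scatter. Compound 4 is therefore estimated at 85%, between 70% and 96%, expected as a number 1 percentage points higher from compound 1 to compound 4 (within the scatter).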

Compound 4, percent of the compound remaining: "not active" (no number reported)
Nothing numeric was reported for compound 4; the estimate stays without a comparison.
By their numbers in this assay, from the lowest: compounds 1 and 3 (each within the scatter of the next); then compound 2.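

Going by these compounds alone, compound 4 was reported in this assay as "not active", without a number, so no step from compound 1 or any other compound to compound 4 can be read. Going by these compounds, whether cyclopropyl in place of isopropyl on this carbonyl carbon changes the percent remaining stays open. Nothing available explains this result.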